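Solubility of three thiazolidinedione-type analogues and one expected newcomer

The compounds below may be only part of what the source reports. "The series", "measured", "known", "first", "only" and "open" are said of these compounds alone.

Measured in a physicochemical assay for solubility, in phosphate buffer, measured as kinetic solubility; a lower number here means a less soluble compound, a higher number a more soluble compound:
compound 1 `CC(C)[C@@H](C[C@H]1SC(=O)NC1=O)c1ccc(-c2ccc3cccc(F)c3c2)[nH]c1=O` gives 23900 nM
compound 2 `O=C1NC(=O)/C(=C/C(c2ccc(-c3ccc4cccc(F)c4c3)[nH]c2=O)C2CC2)O1` gives 30800 nM
compound 3 `CC(C)[C@H](C[C@@H]1OC(=O)NC1=O)c1ccc(-c2ccc3cccc(F)c3c2)[nH]c1=O` gives 21100 nM

All three share the same core, which carries a fluorine-bearing bicyclic aromatic substituent, and differ only in the side chain that links the core to the five-membered heterocycle and in the saturation of that link. Compound 2 gives the highest of the three numbers in this assay, but its gap to compound 1 and its gap to compound 3 both fall within the scatter of repeated measurement, so the three values cannot be told apart with confidence.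

Compound 4 `O=C1NC(=O)/C(=C/C(c2ccccc2)c2ccc(-c3ccc4cccc(F)c4c3)[nH]c2=O)O1` has not yet been measured. It differs from compound 2 in one place: phenyl in place of cyclopropyl on a saturated chain carbon bound to an aromatic carbon and a double-bonded chain carbon. Among the compounds with values here, no measured pair here shows this kind of exchange, so the size of the step from compound 2 to compound 4 can only be expected, not read off. Because compound 2 gives 30800 nM, and the exchange adds three heavy atoms and an aromatic ring in place of a three-membered ring, compound 4 is expected to sit lower in this assay, by a step that goes beyond the scatter, written as a 2.8-fold lower number from compound 2 to compound 4 (0.45 log units; beyond the scatter).

Compound 4 is estimated to give 11000 nM in this assay, with a plausible range from 4500 nM to 26000 nM.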

Compound 4, solubility: 32800 nM
For compound 4 the middle estimate is 3.0-fold (0.47 log units) below the measured one; the measured number lies above the stated range.
By their numbers in this assay, from the lowest: compounds 3, 1, 2 and 4 (each within the scatter of the next).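

In this assay, phenyl in place of cyclopropyl on a saturated chain carbon bound to an aromatic carbon and a double-bonded chain carbon gives a 1.1-fold higher number from compound 2 to compound 4 (0.03 log units; within the scatter) and so leaves the two compounds indistinguishable. Within the data shown here, the earlier compounds offered no pair differing at this place alone, so this pair is the first direct reading of it. Here, a six-membered aromatic ring of carbon with 6 heavy atoms stands where a three-membered non-aromatic ring with 3 heavy atoms stood, and the two numbers cannot be separated. No measurement at hand explains this outcome.

This single pair speaks only for phenyl and cyclopropyl at this place, with the rest of compound 2 kept intact. Going by these compounds, whether an amine, a carboxylic acid or a longer chain at the same place would also give a number within the scatter of compound 2 remains open, as does whether phenyl would give the same reading on the saturated chains of compound 1 and compound 3.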